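Methoxy in place of trifluoromethyl: working notes

The source may hold more compounds than are shown below. What is called first, only, known or untested is meant among the compounds shown, and "the series" means these compounds.

In a functional assay on MDA-MB-231 cells (Homo sapiens) for antiproliferative activity, read by MTT assay, with a stated time of 72 h (a lower number here means a stronger inhibitor, a higher number a weaker inhibitor), compound 1 `CC1=CC[C@H]2[C@H](CC[C@]2(C)O)C(C)(C)[C@@H]1CC[C@H]1[C@]2(C)CC[C@H](OCc3ccccc3)C(C)(C)O[C@H]2CC[C@@]1(C)O` gives 29100 nM, compound 2 `CC1=CC[C@H]2[C@H](CC[C@]2(C)O)C(C)(C)[C@@H]1CC[C@H]1[C@]2(C)CC[C@H](OC(=O)c3ccc([N+](=O)[O-])cc3)C(C)(C)O[C@H]2CC[C@@]1(C)O` gives 8900 nM and compound 3 `CC1=CC[C@H]2[C@H](CC[C@]2(C)O)C(C)(C)[C@@H]1CC[C@H]1[C@]2(C)CC[C@H](OC(=O)c3ccc(C(F)(F)F)cc3)C(C)(C)O[C@H]2CC[C@@]1(C)O` gives 19500 nM. Compound 3 is not separated from compound 1 by more than the scatter, whereas compound 2 has the lowest number of the three, beyond the scatter from both.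

Compound 4 `COc1ccc(C(=O)O[C@H]2CC[C@]3(C)[C@H](CC[C@@](C)(O)[C@H]3CC[C@@H]3C(C)=CC[C@H]4[C@H](CC[C@]4(C)O)C3(C)C)OC2(C)C)cc1` carries methoxy in place of trifluoromethyl on an aromatic carbon, para to a large group: methoxy in place of trifluoromethyl on an aromatic carbon. Within the data shown here, the closest precedent is the exchange of nitro for trifluoromethyl on that same aromatic carbon, which gave a 2.2-fold higher number from compound 2 to compound 3 (0.34 log units; beyond the scatter), a modest step. Replacing benzyl with the (4-nitrophenyl)carbonyl group gave a 3.3-fold lower number from compound 1 to compound 2 (0.51 log units; beyond the scatter), also modest. Replacing benzyl with the (4-(trifluoromethyl)phenyl)carbonyl group gave a 1.5-fold lower number from compound 1 to compound 3 (0.17 log units; within the scatter), which stays within the scatter. Among the measured compounds shown here, no methoxy analogue has a measured value yet, so these steps offer only a rough guide. In this assay no step beyond the scatter is therefore expected, and no firm direction can be assigned. The estimated change is a 1.1-fold lower number from compound 3 to compound 4 (0.06 log units; within the scatter). The expected value for compound 4 is 17000 nM, with an estimated range of 8000 nM to 36000 nM.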

Compound 4, half-maximal inhibitory concentration: 30600 nM
Compound 4: middle estimate off by 1.8-fold (0.26 log units), on the low side, within the range that was stated.
By their numbers in this assay, from the lowest: compound 2; then compounds 3, 1 and 4 (each within the scatter of the next).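

In this assay, the aromatic carbon para to a large group now carries three different substituents across compounds 2, 3 and 4. Methoxy in place of trifluoromethyl gives a 1.6-fold higher number from compound 3 to compound 4 (0.20 log units; within the scatter) and does not separate the two groups, whereas methoxy in place of nitro gives a 3.4-fold higher number from compound 2 to compound 4 (0.54 log units; beyond the scatter) and leaves nitro as the only one of the three substituents that stands apart from the others. The (4-methoxyphenyl)carbonyl group in place of benzyl gives a 1.1-fold higher number from compound 1 to compound 4 (0.02 log units; within the scatter) and, like the (4-(trifluoromethyl)phenyl)carbonyl group, is not separated from benzyl, so having a carbonyl on that oxygen does not by itself set a compound apart; no measurement at hand accounts for the separate position of compound 2.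

From the compounds shown here alone, it remains open whether a nitrile or a carboxylic acid on the same aromatic carbon would stand with nitro or with trifluoromethyl and methoxy. A 4-nitrobenzyl group on the same oxygen would test whether the position of compound 2 depends on nitro alone or on nitro together with the carbonyl.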